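A Triazolyl for an Oxazolyl on the Shared Core

The compounds below may be only part of what the source reports. "The series", "measured", "known", "first", "only" and "open" are said of these compounds alone.

Of the compounds shown here, three sharing a hydroxy- and carboxy-bearing core have been tested in a functional assay on the whole organism for inhibition, with Rattus norvegicus as the target, read by paw edema; on this read-out lower numbers stand for an effect already at smaller amounts and higher numbers for an effect only at larger amounts of compound. Compound 1 `O=C(O)c1ccc(-c2cscn2)cc1O` gives 70 mg/kg, compound 2 `O=C(O)c1cc(-c2cocn2)ccc1O` gives 110 mg/kg, and compound 3 `O=C(O)c1cc(-c2ccccn2)ccc1O` gives 200 mg/kg. Compound 2 thus holds the second highest of the three numbers, yet its gaps to compound 1 and to compound 3 both lie within the scatter of repeated runs, so no order among them can be read. Compound 4 `O=C(O)c1cc(-n2cnnc2)ccc1O` differs from compound 2 by 4H-1,2,4-triazol-4-yl in place of 1,3-oxazol-4-yl on an aromatic carbon. Going by the values given here, no measured pair shows such an exchange, so the expectation rests on the narrow spread of the three known values. In this assay the expected step is a 1.2-fold higher number from compound 2 to compound 4 (0.07 log units; within the scatter), not beyond the scatter. Compound 4 is therefore estimated at 130 mg/kg, within a range from 55 mg/kg to 300 mg/kg.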

Compound 4, dose for half-maximal effect: > 250 mg/kg
Compound 4: a limit, no number (the forecaster's own chance of this, stated with the estimate: 10%); middle value at least 1.9-fold (0.28 log units) away from the limit.
By their numbers in this assay, from the lowest: compounds 1, 2 and 3 (each within the scatter of the next, the first and the last beyond it). At a limit, above all of these: compound 4.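

Going by these compounds alone, at the position meta to a carboxy group and para to a hydroxy group, 4H-1,2,4-triazol-4-yl in place of 1,3-oxazol-4-yl gives the first single-place step in this assay: an at least 2.2-fold higher number from compound 2 to compound 4 (0.35 log units; beyond the scatter). This position therefore does not treat these two groups alike, although both are five-membered aromatic rings with no net charge. How large the step really is stays unknown, since compound 4 gives a limit and not a number: the limit of > 250 mg/kg in this assay, at which 1 of the 4 values shown sits.

As far as these compounds go, it remains open whether an amine or a phenyl ring at this position would stand nearer compound 2 or compound 4. Also open, from the compounds shown here alone, is whether the same exchange on the core of compound 1 would give a similar step.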